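Compound 4: changing the group on a carbonyl carbon

This account rests on a few compounds, and the source may have more. Where it says the series, first, only, none or still open, it means among the compounds named here.

Measured in an ADME assay on microsomes from liver (Mus musculus) for metabolic stability, with a stated time of 10 min; on this read-out higher numbers stand for a more stable compound and lower numbers for a less stable compound:
- Compound 1 `CCC[C@]1(C(=O)N2CC[C@](c3ccc(C(F)(C(F)(F)F)C(F)(F)F)cc3)(S(=O)(=O)c3ccc(F)cc3)C2)CC[C@H](C(=O)O)CC1` gives "not determined" (no result reported)
- Compound 2 `C[C@]1(C(=O)N2CC[C@](c3ccc(C(F)(C(F)(F)F)C(F)(F)F)cc3)(S(=O)(=O)c3ccc(F)cc3)C2)CC[C@@H](C(=O)O)CC1` gives 100%
- Compound 3 `O=C(O)C12CCC(C(=O)N3CC[C@](c4ccc(C(F)(C(F)(F)F)C(F)(F)F)cc4)(S(=O)(=O)c4ccc(F)cc4)C3)(CC1)CC2` gives 73%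

Compound 3 holds the lower of the two numbers available, and compound 2 stands above it. Compound 1 offers no number for comparison.

Compound 4 `O=C([C@H]1CC[C@H](c2nnn[nH]2)CC1)N1CC[C@](c2ccc(C(F)(C(F)(F)F)C(F)(F)F)cc2)(S(=O)(=O)c2ccc(F)cc2)C1` has not yet been measured. It carries a 4-(1H-tetrazol-5-yl)cyclohexyl group on the carbonyl carbon where compound 3 carries its own two-ring group. The full change is a group of 11 heavy atoms (7 carbon, 4 nitrogen; one five-membered aromatic ring with 4 hetero atoms, one six-membered non-aromatic ring of carbon only) in place of a group of 11 heavy atoms (9 carbon, 2 oxygen; 2 six-membered non-aromatic rings of carbon only), on a carbonyl carbon and the rest of the structure stays the same.

Among the compounds with values here, only one measured step involves this place: a number 27 percentage points lower from compound 2 to compound 3 (beyond the scatter) in this assay. Compound 2, with one six-membered non-aromatic ring of carbon only in this group, reaches 100% in the same test, and compound 4 shares that ring count. Within the data shown here, this offers a weak hint of a small rise, but one step is thin evidence, and no measured compound here carries the five-membered aromatic ring. The estimated change is a number 7 percentage points higher from compound 3 to compound 4 (within the scatter) and no step beyond the scatter is expected. Compound 4 is expected at 80% in this assay with 58% to 100% as the estimated range.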

Compound 4, percent of the compound remaining: 73%
Compound 4: the middle estimate sits 7 percentage points above what was measured, and the stated range covers the measured number.
By their numbers in this assay, from the lowest: compounds 3 and 4 (each within the scatter of the next); then compound 2.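

In this assay, within the data shown here, compound 4 is the first compound here whose group on the carbonyl carbon holds a tetrazole ring and no carboxylic acid, and the change gives no change at the digits printed from compound 3 to compound 4 (within the scatter). So at this position, the 4-(1H-tetrazol-5-yl)cyclohexyl group and the two-ring group of compound 3 cannot be told apart on this read-out. The single six-membered ring that compound 4 shares with compound 2 does not keep the number at the level of compound 2, since the change gives a number 27 percentage points lower from compound 2 to compound 4 (beyond the scatter), and no measurement shown here explains this drop.

The group in compound 2 differs from that in compound 4 in both its methyl group and its carboxylic acid, so this step cannot show which of them matters, and a 4-carboxycyclohexyl group without the methyl or a 1-methylcyclohexyl group bearing the tetrazole would separate the two. With no number for compound 1, the compounds shown also leave open what a propyl chain in place of that methyl group does on this read-out.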